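A few compounds are considered here, and "the series" means these few. Any claim that something is new, unique, unknown or untested is made for them only; others in the source may bear on it.

Compound 1 (`CCOc1cc2[nH]c(Cc3nn(CC(=O)O)c(=O)c4ccccc34)nc2cc1Cl`) gives 361000 nM
Compound 2 (`O=C(O)Cn1nc(Cn2cc3cc(OCC4CC4)c(Cl)cc3n2)c2ccccc2c1=O`) gives 3140000 nM

In an ADME assay on the whole organism (Mus musculus, strain CD1) for pharmacokinetics, read by LC-MS, with a stated time of 24 h, at a dose of 5 mg/kg by the oral route (on this read-out lower numbers stand for lower exposure and higher numbers for higher exposure at the dose given), compound 2 gives 3140000 nM and stands highest of the two measured compounds, while compound 1 gives 361000 nM and lies lower by more than the usual scatter. Compound 3 (`C[C@H](C(=O)O)n1nc(Cn2cc3cc(OCC4CC4)c(Cl)cc3n2)c2ccccc2c1=O`) has not yet been measured. It differs from compound 2 in one place: methyl in place of hydrogen on a saturated chain carbon bound to an aromatic nitrogen and a carbonyl carbon and the change is methyl in place of hydrogen on a saturated chain carbon bound to an aromatic nitrogen and a carbonyl carbon, so that carboxymethyl becomes 1-carboxyethyl. Among the compounds with values here, no measured pair shows this change, and compound 1 and compound 2 differ in more than one place, so the data offer no direct guide to its size. Compound 3 is expected to stay close to compound 2 at 3140000 nM with no step beyond the scatter, leaning slightly towards a lower number. The expected step is a 1.3-fold lower number from compound 2 to compound 3 (0.10 log units; within the scatter) on this estimate. In this assay the estimate for compound 3 is 2500000 nM with 800000 nM to 7000000 nM as the expected range.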

Compound 3, maximal plasma concentration: 4750000 nM
Compound 3: the middle estimate sits 1.9-fold (0.28 log units) below what was measured; the measured number falls inside the stated range.
By their numbers in this assay, from the lowest: compound 1; then compounds 2 and 3 (each within the scatter of the next).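

In this assay, within the data shown here, the first step confined to a single place shows a 1.5-fold higher number from compound 2 to compound 3 (0.18 log units; within the scatter) for methyl in place of hydrogen on a saturated chain carbon bound to an aromatic nitrogen and a carbonyl carbon, so the read-out does not tell carboxymethyl from 1-carboxyethyl in this pair. The earlier compounds shown here could not show this, since compound 1 and compound 2 differ in more than one place, and only now is there a direct reading at this position: here it takes the added methyl with no change beyond the scatter. No measurement shown speaks to what lies behind this outcome.

The compounds shown leave open whether a longer chain such as ethyl, two methyl groups on the same carbon, or a ring such as cyclopropyl at this position would also stay within the scatter of compound 2. On these data alone, it also remains open whether an amide or a tetrazole could stand in for the carboxylic acid at this position, and whether the methyl would give a similar step on the core of compound 1.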